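The compounds below may be only part of what the source reports. "The series", "measured", "known", "first", "only" and "open" are said of these compounds alone.

Working notes on the thiocarbonyl-ring series. Compound 1 `Cc1ccnc(/C(N)=N/NC(=S)N2CCSCC2)c1` gives 74.2% in a functional assay on MCF7 cells (Homo sapiens) for cytotoxicity, read by MTT assay, with a stated time of 72 h, tested at 30 uM; on this read-out lower numbers stand for less inhibition of growth and higher numbers for more inhibition of growth at the one concentration tested; compound 2 `N/C(=N\NC(=S)N1CCCC1)c1ccccn1` gives 54.6%; compound 3 `Cc1ccnc(/C(N)=N/NC(=S)N2CCCCC2)c1` gives 61.7%. Among the measured compounds shown here, compound 3 thus stands second of the three numbers: its gap to compound 2 is within the scatter, its gap to compound 1 is beyond it, the step of a number 12.5 percentage points lower from compound 1 to compound 3 (beyond the scatter) being the only measured change at the thiocarbonyl carbon. Compound 4 `Cc1ccnc(/C(N)=N/NC(=S)N2CCCC2)c1` differs from compound 3 by pyrrolidin-1-yl in place of piperidin-1-yl on a thiocarbonyl carbon. For the measured compounds named here, that change has no direct measured counterpart. Going by the values given here, the one related step, from thiomorpholin-4-yl to piperidin-1-yl, was modest. Compound 2 carries the same pyrrolidin-1-yl as compound 4, though without the methyl on the shared core, and compound 2 with 54.6% lies within the scatter of compound 3. A step of at most modest size, if any, is therefore expected in this assay, leaning downward, a number 4.7 percentage points lower from compound 3 to compound 4 (within the scatter). Compound 4 is estimated at 57%, with a range from 42% to 72%.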

Compound 4, percent growth inhibition at one concentration: 82.2%
Estimate against measurement, compound 4: 25.2 percentage points below; the measured number lies above the stated range.
By their numbers in this assay, from the lowest: compounds 2 and 3 (each within the scatter of the next); then compounds 1 and 4 (each within the scatter of the next).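

In this assay the group on the thiocarbonyl carbon proves able to shift the number with a change from a six-membered to a five-membered ring alone, with a number 20.5 percentage points higher from compound 3 to compound 4 (beyond the scatter) on pyrrolidin-1-yl in place of piperidin-1-yl. Among the compounds shown here, the first reading of the methyl in place of hydrogen on an aromatic carbon gives a number 27.6 percentage points higher from compound 2 to compound 4 (beyond the scatter), so pyrrolidin-1-yl does not set the level by itself. Pyrrolidin-1-yl in place of thiomorpholin-4-yl gives a number 8 percentage points higher from compound 1 to compound 4 (within the scatter), which leaves those two groups unordered, while piperidin-1-yl stands beyond the scatter from both. No measurement at hand accounts for these steps.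

Open, going by these compounds, is how a morpholin-4-yl ring or an open-chain dimethylamino group on the thiocarbonyl carbon would compare. On these data alone, the methyl step is also known only with pyrrolidin-1-yl, so its size with other groups at that carbon remains open.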